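Series notes: the step from compound 3 to compound 4

This account rests on a few compounds, and the source may have more. Where it says the series, first, only, none or still open, it means among the compounds named here.

Measured compounds:
compound 1, `CCCCNc1nc(N)nc2cc(OC)ccc12`, 0.3 uM
compound 2, `CCCCNc1nc(N)nc2cccc(OC)c12`, 0.1 uM
compound 3, `CCCCNc1nc(N)nc2cccc(CCc3ccccc3)c12`, 0.47 uM

In an ADME assay on HEK293 cells for agonist activity at Toll-like receptor 8 (Homo sapiens), read by a luciferase reporter, with a stated time of 6 h (a lower number here means that less compound is needed, a higher number that more compound is needed for the effect), compound 3 gives 0.47 uM, the highest of the three numbers. Compound 1 gives 0.3 uM, which lies within the scatter of compound 3. Compound 2 gives 0.1 uM, and the step of a 4.7-fold higher number from compound 2 to compound 3 (0.67 log units; beyond the scatter) is beyond the scatter.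

Compound 4, `CCCCNc1nc(N)nc2cccc(OCc3cccnc3)c12`, has not yet been measured in this assay. It differs from compound 3 in one place: (pyridin-3-yl)methoxy in place of phenethyl on an aromatic carbon.

Going by the values given here, the only measured step that bears on this change is a 4.7-fold higher number from compound 2 to compound 3 (0.67 log units; beyond the scatter), in which methoxy at the same place gave way to phenethyl. The entering (pyridin-3-yl)methoxy group shares the oxygen attachment of methoxy and the ring of phenethyl, so neither measured compound matches it directly, and nothing in the series shows the effect of the added ring nitrogen. Compound 4 is therefore expected to land between the numbers of compound 2 and compound 3. Compound 4 is expected to show a step of a 1.9-fold lower number from compound 3 to compound 4 (0.27 log units; within the scatter), which may not clear the scatter. The estimate for compound 4 in this assay is 0.25 uM, with a range from 0.08 uM to 0.8 uM.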

Compound 4, minimum effective concentration: 0.53 uM
Compound 4: the middle estimate sits 2.1-fold (0.33 log units) below what was measured, and the stated range covers the measured number.
By their numbers in this assay, from the lowest: compound 2; then compounds 1, 3 and 4 (each within the scatter of the next).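

In this assay, the exchange of phenethyl for (pyridin-3-yl)methoxy on this aromatic carbon is a 1.1-fold higher number from compound 3 to compound 4 (0.05 log units; within the scatter), so the two groups are not told apart by this read-out, although the entering group brings an oxygen link, a ring nitrogen and hydrogen-bond acceptors that the leaving group lacks. Adding pyridin-3-yl to the saturated chain carbon of the methoxy group gives a 5.3-fold higher number from compound 2 to compound 4 (0.72 log units; beyond the scatter), the first view of this change made with the oxygen link kept in place. Together with a 4.7-fold higher number from compound 2 to compound 3 (0.67 log units; beyond the scatter), this shows that at this place compound 3 and compound 4 both stand beyond the scatter from compound 2, with or without that oxygen link.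

A benzyloxy group here would separate the ring nitrogen from the oxygen link, which compound 3 and compound 4 change together. An ethoxy group, a longer alkoxy chain or an alkoxy chain ending in an amine would show whether the step away from methoxy needs an aromatic ring at all. Nothing in the available data accounts for these results.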